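A trichlorophenyl in place of 2,3-dichlorophenyl

The compounds below may be only part of what the source reports. "The series", "measured", "known", "first", "only" and "open" are said of these compounds alone.

Compound 1 `NC1=NC2(CCSCC2)N(OCCCOc2ccc(Cl)c(Cl)c2)C(N)=N1` gives 140 nM
Compound 2 `NC1=NC2(CCSCC2)N(OCCCOc2cccc(Cl)c2)C(N)=N1` gives 260 nM
Compound 3 `NC1=NC2(CCSCC2)N(OCCCOc2cccc(Cl)c2Cl)C(N)=N1` gives 30 nM

In a functional assay on HL-60 cells (Homo sapiens) for antiproliferative activity, read by MTT assay, with a stated time of 72 h (on this read-out higher numbers stand for weaker inhibition and lower numbers for stronger inhibition), compound 3 gives 30 nM and stands lowest of the three. Compound 4 `NC1=NC2(CCSCC2)N(OCCCOc2cc(Cl)c(Cl)cc2Cl)C(N)=N1` has 2,4,5-trichlorophenyl in place of 2,3-dichlorophenyl on an oxygen on a saturated carbon. Among the measured compounds shown here, no measured step makes this change directly. Hydrogen in place of chloro gave a 1.9-fold higher number from compound 1 to compound 2 (0.27 log units; within the scatter) and so stayed small, chloro in place of hydrogen gave an 8.7-fold lower number from compound 2 to compound 3 (0.94 log units; beyond the scatter) and 2,3-dichlorophenyl in place of 3,4-dichlorophenyl gave a 4.7-fold lower number from compound 1 to compound 3 (0.67 log units; beyond the scatter) as well. An extra chloro thus lowered the number clearly only on reaching 2,3-dichlorophenyl, and compound 4 no longer carries that group. A modest move to a higher number, meaning weaker inhibition, is therefore expected (a 2.3-fold higher number from compound 3 to compound 4 (0.37 log units; beyond the scatter)). In this assay compound 4 is estimated at 70 nM with an expected range (20 nM to 220 nM).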

Compound 4, half-maximal inhibitory concentration: 730 nM
Beside the measured number, compound 4's estimate is 10-fold (1.02 log units) below it, outside the stated range (above it).
By their numbers in this assay, from the lowest: compound 3; then compounds 1 and 2 (each within the scatter of the next); then compound 4.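

In this assay, a further chloro on the aromatic ring did not bring a lower number here: 2,4,5-trichlorophenyl gave a 24-fold higher number from compound 3 to compound 4 (1.39 log units; beyond the scatter), a 2.8-fold higher number from compound 2 to compound 4 (0.45 log units; beyond the scatter) and a 5.2-fold higher number from compound 1 to compound 4 (0.72 log units; beyond the scatter). Adding a chloro at this position can therefore move the number in either direction, depending on the chlorophenyl group that receives it: the same change on two cores in this assay, an 8.7-fold lower number (0.94 log units; beyond the scatter) from compound 2 to compound 3 and a 5.2-fold higher number (0.72 log units; beyond the scatter) from compound 1 to compound 4, 45-fold (1.66 log units) apart, beyond the scatter of two such steps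

The compounds shown leave open whether the low number of compound 3 would hold with fluoro or methoxy in place of chloro on the 2,3-dichlorophenyl group. They also leave open what a longer chain on the oxygen would do.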